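Lengthening the nitrile chain in a non-cytotoxic series

This account rests on a few compounds, and the source may have more. Where it says the series, first, only, none or still open, it means among the compounds named here.

Compound 1 `CC(C)Cn1nc(C(=O)N[C@H]2COc3ccccc3N(C)C2=S)nc1Cc1ccccc1` was examined in a toxicity assay on HT-29 cells (Homo sapiens) for cytotoxicity; a lower number here means that less compound is tolerated, a higher number that more compound is tolerated. In this assay compound 1 gives > 100000 nM, which is a limit of the assay and not a number. Two relatives sharing the core of compound 1 were measured alongside it. Compound 2 `COCCn1nc(C(=O)N[C@H]2COc3ccccc3N(C)C2=S)nc1Cc1ccccc1` gives > 100000 nM in this assay, again a limit. Compound 3 `CN1C(=S)[C@@H](NC(=O)c2nc(Cc3ccccc3)n(CCCCC#N)n2)COc2ccccc21` gives > 100000 nM in this assay, also a limit. All three values thus rest at the limit of > 100000 nM in this assay, at which 3 of the 3 values shown sit. The steps among them, a step that the two limits leave unreadable from compound 1 to compound 2, a step that the two limits leave unreadable from compound 1 to compound 3 and a step that the two limits leave unreadable from compound 2 to compound 3, therefore carry no readable size.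

Compound 4 `CN1C(=S)[C@@H](NC(=O)c2nc(Cc3ccccc3)n(CCCCCC#N)n2)COc2ccccc21` has not yet been measured. It differs from compound 1 by 4-cyanobutyl in place of isopropyl on a saturated chain carbon bound to an aromatic nitrogen. The nearest measured step is a step that the two limits leave unreadable from compound 1 to compound 3, in which a shorter nitrile chain already replaced the isopropyl; the steps a step that the two limits leave unreadable from compound 1 to compound 2 and a step that the two limits leave unreadable from compound 2 to compound 3 are equally unreadable. No measured step gives a size or a direction for the present change, and every compound shown so far sits at the limit. Compound 4 is therefore expected to give 150000 nM in this assay, within a range from 50000 nM to 500000 nM. This estimate means an expected step that the limit leaves unreadable from compound 1 to compound 4, no change beyond the scatter, with the value most likely reported again as a limit.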

Compound 4, half-maximal cytotoxic concentration: > 100000 nM
Compound 4: only a limit was reported; the forecaster's own chance of this, stated with the estimate: 90%; the middle value lies beyond the limit too.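

In this assay compound 4 gives > 100000 nM as a limit of the assay and not a number. Its steps from compound 1, compound 2 and compound 3 therefore cannot be read, since all four compounds sit at the same limit: the limit of > 100000 nM in this assay, at which 4 of the 4 values shown sit. The compounds shown leave open at what concentration, if any, cytotoxicity would appear, and whether the chain on the aromatic nitrogen changes it.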